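The compounds below may be only part of what the source reports. "The series", "measured", "known", "first", "only" and "open" are said of these compounds alone.

Of the compounds shown here, three of a shared core have been measured in an assay on cell membranes for displacement of a labelled ligand from corticotropin-releasing factor receptor 1 (Rattus norvegicus); on this read-out higher numbers stand for weaker inhibition and lower numbers for stronger inhibition. Compound 1 `CCN(CC)c1nc(C)nc2c(-c3cc(OC)c(OC)cc3Br)c(C)nn12` gives 4.06 nM, compound 2 `COCC(COC)Nc1nc(C)nc2c(-c3ccc(OC)cc3C)c(C)nn12` gives 9.7 nM, and compound 3 `CCC(CC)Nc1nc(C)nc2c(-c3ccc(OC)cc3)c(C)nn12` gives 3.8 nM. Compound 2 therefore stands with the highest number of the three, and both other numbers lie far enough below it to fall beyond the usual scatter, so on these figures compound 2 is the weakest inhibitor of the group.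

The step under consideration leads from compound 2 to compound 4 `CCCN(CCC#N)c1nc(C)nc2c(-c3ccc(OC)cc3C)c(C)nn12`. The change is (2-cyanoethyl)(propyl)amino in place of (2-methoxy-1-(methoxymethyl)ethyl)amino on an aromatic carbon. The aromatic part carrying the methoxy and methyl groups is kept, and only the amino substituent on the core is exchanged, the two ether oxygens and the hydrogen-bond donor giving way to a nitrile on a short chain.

Since compound 1 and compound 3, whose amino groups carry only carbon chains, both give lower numbers than compound 2, a move toward a chain-only amine in compound 4 is expected to bring the number down moderately, by about a 1.9-fold lower number from compound 2 to compound 4 (0.29 log units; within the scatter) in this assay. Compound 4 is thus estimated at 5 nM, with a likely range from 1.5 nM to 15 nM.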

Compound 4, half-maximal inhibitory concentration: 2.16 nM
Beside the measured number, compound 4's estimate is 2.3-fold (0.36 log units) above it; low and high end bracket the measured number.
By their numbers in this assay, from the lowest: compounds 4, 3 and 1 (each within the scatter of the next); then compound 2.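

With the aromatic part carrying the methoxy and methyl groups held fixed, replacing (2-methoxy-1-(methoxymethyl)ethyl)amino with (2-cyanoethyl)(propyl)amino on the aromatic carbon between two ring nitrogen atoms gives a clear gain in this assay (a 4.5-fold lower number from compound 2 to compound 4 (0.65 log units; beyond the scatter)). Among the compounds shown here, because compounds 1, 2 and 3 all differ from one another in more than one place, this is the first comparison that isolates the amino group, and it shows that this group alone can shift the number beyond the scatter. The entering group has the same count of heavy atoms as the one it replaces but no hydrogen-bond donor and no oxygen, so the number at this position does not depend on keeping the donor or the ether oxygens, although nothing measured here identifies which part of the exchange produces the step.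

A dipropylamino group on the same core and aromatic part would separate the contribution of the nitrile from that of the other changes in this exchange. Going by these compounds, it also remains open whether (2-cyanoethyl)(propyl)amino gives a similar step when the aromatic part is a different one, such as the bromo- and dimethoxy-substituted ring of compound 1.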